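Removing a Methoxy Group from the Weakest Analogue

This account rests on a few compounds, and the source may have more. Where it says the series, first, only, none or still open, it means among the compounds named here.

Of the compounds shown here, three sharing one core have been tested in a functional assay on K562 cells (Homo sapiens) for antiproliferative activity, read by resazurin assay, with a stated time of 72 h; a higher number here means a weaker inhibitor, a lower number a stronger inhibitor. Compound 1 `N#Cc1c(-c2ccco2)nc2c(c(-c3ccccc3)nn2-c2ccccc2)c1-c1ccc(O)cc1` gives 4200 nM. Compound 2 `COc1ccc(-c2nc3c(c(-c4ccccc4)nn3-c3ccccc3)c(-c3ccc(O)cc3)c2C#N)cc1`, which carries 4-methoxyphenyl in place of furan-2-yl, gives 2100 nM; the step of a 2.0-fold lower number from compound 1 to compound 2 (0.30 log units; within the scatter) is within the scatter, so these two cannot be ranked. Compound 3 `COc1cc(-c2c(C#N)c(-c3cccs3)nc3c2c(-c2ccccc2)nn3-c2ccccc2)ccc1O` gives 15400 nM, the highest of the three numbers, beyond the scatter from both compound 1 and compound 2.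

Compound 4 `N#Cc1c(-c2cccs2)nc2c(c(-c3ccccc3)nn2-c2ccccc2)c1-c1ccc(O)cc1` follows from compound 3 by one change: hydrogen in place of methoxy on an aromatic carbon. Going by the values given here, the only measured step, from compound 1 to compound 2, concerns a different position of the core and does not bear on this change. Among the compounds with values here, compound 4 does, however, share the 4-hydroxyphenyl group with compound 1 and compound 2, both of which sit well below compound 3, while no measured pair isolates the methoxy group itself.

Within the data shown here, with no direct precedent, the expectation is a drop toward the level of compound 1, with wide uncertainty. Compound 4 is therefore expected to give a step of a 3.1-fold lower number from compound 3 to compound 4 (0.49 log units; beyond the scatter) in this assay. The estimated value for compound 4 is 5000 nM, with a range from 1500 nM to 16000 nM.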

Compound 4, half-maximal inhibitory concentration: 11600 nM
The estimate for compound 4 lay 2.3-fold (0.37 log units) below the measured number, within the range that was stated.
By their numbers in this assay, from the lowest: compounds 2 and 1 (each within the scatter of the next); then compounds 4 and 3 (each within the scatter of the next).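

In this assay, going from the 4-hydroxy-3-methoxyphenyl group to the 4-hydroxyphenyl group gives a 1.3-fold lower number from compound 3 to compound 4 (0.12 log units; within the scatter), so at this place, ortho to a hydroxy group, methoxy and hydrogen cannot be told apart. With the 4-hydroxyphenyl group now held fixed, the other varied place can be compared directly: thiophen-2-yl in place of furan-2-yl gives a 2.8-fold higher number from compound 1 to compound 4 (0.44 log units; beyond the scatter), and thiophen-2-yl in place of 4-methoxyphenyl gives a 5.5-fold higher number from compound 2 to compound 4 (0.74 log units; beyond the scatter). Among these single changes, only those two steps lie beyond the scatter, so in this small set the number moves with the group at that other place and not with the methoxy group. Nothing measured here explains the size of any of these steps.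

Methoxy and hydrogen are the only two groups shown at the place ortho to the hydroxy group, so it remains open whether a chlorine atom, an amine or a longer chain such as propoxy there would shift the number. As far as these compounds go, it is also open whether removing the methoxy group would give the same result with furan-2-yl or 4-methoxyphenyl in place of thiophen-2-yl.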